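A few compounds are considered here, and "the series" means these few. Any claim that something is new, unique, unknown or untested is made for them only; others in the source may bear on it.

For the measured compounds named here, in an in vitro ADME assay on microsomes from liver (Homo sapiens) for metabolic stability, tested at 1 mg/mL (a lower number here means that the compound disappears faster, a higher number that the compound lasts longer), compound 1 (`O=C(Nc1cc2cc[nH]c(=O)c2cc1Cl)C1CNCC1c1ccccn1`) gives 0.967 h, the only actual number so far. Compound 2 (`CN1CCC(C(=O)Nc2cc3cc[nH]c(=O)c3cc2Cl)CC1`) gives > 5 h, which is a limit of the assay and not a number. Going by the values given here, no measured pair differs in one place only, so the data offer no step to scale from.

Compound 3 (`O=C(Nc1cc2cc[nH]c(=O)c2cc1Cl)C1CNCC1c1cccc(Br)c1`) keeps the core of compound 1 and has 3-bromophenyl in place of pyridin-2-yl on a saturated ring carbon. In this assay, a small move towards a shorter half-life is expected, with compound 1 at 0.967 h as the only anchor, and it may not clear the usual scatter. The expected change is a 1.6-fold lower number from compound 1 to compound 3 (0.21 log units; within the scatter). The estimate for compound 3 is 0.6 h, with an expected range of 0.25 h to 1.4 h.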

Compound 3, half-life: 0.717 h
Estimate against measurement, compound 3: 1.2-fold (0.08 log units) below, and the stated range covers the measured number.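

For the compounds shown here, on the saturated ring carbon, two ring bonds from the ring nitrogen, 3-bromophenyl in place of pyridin-2-yl gives the first readable step in this assay, a 1.3-fold lower number from compound 1 to compound 3 (0.13 log units; within the scatter), so this exchange of one aromatic ring for another does not separate compound 3 from compound 1. The step takes out the aromatic ring nitrogen with its hydrogen-bond acceptor and brings in bromine, and at this position the half-life does not move beyond the scatter. Nothing measured here bears on the reason for this step.

A plain phenyl group would separate the departure of the aromatic ring nitrogen from the arrival of the bromine. Also open, going by these compounds, is how an amine or a carboxylic acid on this aromatic ring would read in this assay.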